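Swapping Chloro for Oxanyloxy: Outlook on Cytotoxicity

A few compounds are considered here, and "the series" means these few. Any claim that something is new, unique, unknown or untested is made for them only; others in the source may bear on it.

Three compounds have been measured so far:
Compound 1, `Cc1cn([C@@H]2C[C@H](O)[C@@H](CNC(=O)Nc3ccc(Cl)cc3)O2)c(=O)[nH]c1=O`, gives > 50000 nM in an ADME assay on MRC5 cells (Homo sapiens) for cytotoxicity; on this read-out higher numbers stand for lower toxicity in this test and lower numbers for higher toxicity in this test; this value is a limit of the assay, not a number.
Compound 2, `Cc1cn([C@@H]2C[C@H](O)[C@@H](CNC(=O)Nc3ccccc3COc3ccccc3)O2)c(=O)[nH]c1=O`, gives > 50000 nM in this assay; this too is a limit.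
Compound 3, `Cc1cn([C@@H]2C[C@H](O)[C@@H](CNC(=S)Nc3ccc(OCc4ccccc4)cc3)O2)c(=O)[nH]c1=O`, gives > 50000 nM in this assay; again only a limit.

Compound 1 therefore sits at the limit of > 50000 nM in this assay, at which 3 of the 3 values shown sit. No separate value can be read for it, so it cannot be ranked against compound 2 or compound 3; all that can be said is that none of the three reaches a measurable toxicity in this assay.

The unmeasured compound is compound 4, `Cc1cn([C@@H]2C[C@H](O)[C@@H](CNC(=O)Nc3ccc(OC4CCOCC4)cc3)O2)c(=O)[nH]c1=O`. It differs from compound 1 in a single change: (oxan-4-yl)oxy in place of chloro on an aromatic carbon.

Within the data shown here, since no step between measured compounds is available, there is nothing here to suggest that this change would move the read-out in either direction beyond the usual scatter. Compound 4 is expected to stay at the limit as well, with the step that the limit leaves unreadable from compound 1 to compound 4 expected to be no more than scatter. The estimate for compound 4 in this assay is 60000 nM, within a range from 30000 nM to 200000 nM.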

Compound 4, half-maximal cytotoxic concentration: > 50000 nM
Compound 4 was reported as a limit; the forecaster's own chance of this, stated with the estimate: 85%; the middle value does not contradict the limit.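

Compound 4 and compound 1 are both reported only as limits of the assay, so no size can be read for the swap of chloro for (oxan-4-yl)oxy, and no new step follows: the limit of > 50000 nM in this assay, at which 4 of the 4 values shown sit.

The compounds shown leave open whether this swap moves the read-out in this assay at all, and how the four compounds rank against one another.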